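The source may hold more compounds than are shown below. What is called first, only, known or untested is meant among the compounds shown, and "the series" means these compounds.

Working notes on the sulfonyl variation of the shared core. Compound 1 `Cc1ccc2[nH]c(C(=O)N[C@H]3CCN(S(=O)(=O)c4ccccc4)C[C@@H]3C(=O)NCCN(C)C)cc2c1` gives 16 uL/min in an ADME assay on cells (Hepatocyte, Rattus norvegicus) for metabolic stability; on this read-out higher numbers stand for fast clearance and lower numbers for slow clearance. Compound 2 `Cc1ccc2[nH]c(C(=O)N[C@H]3CCN(S(=O)(=O)c4cccnc4)C[C@@H]3C(=O)NCCN(C)C)cc2c1` gives 5 uL/min in this assay, and compound 3 `Cc1ccc2[nH]c(C(=O)N[C@H]3CCN(S(=O)(=O)C4CC4)C[C@@H]3C(=O)NCCN(C)C)cc2c1` gives 7 uL/min; among the three measured numbers compound 3 stands second highest, with compound 2 within the scatter of it and compound 1 beyond it. The measured steps at the sulfonyl sulfur were a 2.3-fold lower number from compound 1 to compound 3 (0.36 log units; beyond the scatter) and a 1.4-fold higher number from compound 2 to compound 3 (0.15 log units; within the scatter). Compound 4 `Cc1ccc2[nH]c(C(=O)N[C@H]3CCN(S(=O)(=O)N4CCCCC4)C[C@@H]3C(=O)NCCN(C)C)cc2c1` is the next variant: piperidin-1-yl in place of cyclopropyl on a sulfonyl sulfur. Going by the values given here, no measured step carries this exact change; the two changes at the same position gave only modest or in-scatter steps, so no step beyond the scatter is expected, a 1.3-fold higher number from compound 3 to compound 4 (0.11 log units; within the scatter). Compound 4 is estimated at 9 uL/min, with a range of 4 uL/min to 20 uL/min.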

Compound 4, intrinsic clearance in a liver preparation (reported as CLH), per the amount of preparation that the assay uses: 25 uL/min
For compound 4 the middle estimate is 2.8-fold (0.44 log units) below the measured one; measured number above the stated range.
By their numbers in this assay, from the lowest: compounds 2 and 3 (each within the scatter of the next); then compounds 1 and 4 (each within the scatter of the next).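

At this position in this assay, a non-aromatic ring on the sulfonyl sulfur does not by itself keep the number low: piperidin-1-yl in place of cyclopropyl gives a 3.6-fold higher number from compound 3 to compound 4 (0.55 log units; beyond the scatter), and in place of pyridin-3-yl it gives a 5.0-fold higher number from compound 2 to compound 4 (0.70 log units; beyond the scatter). Both steps exceed every earlier step at this sulfur, whereas piperidin-1-yl in place of phenyl gives a 1.6-fold higher number from compound 1 to compound 4 (0.19 log units; within the scatter). Nothing available explains the difference between the two non-aromatic rings. Open, from the compounds shown here alone, is whether a smaller dimethylamino group or a morpholin-4-yl ring on the sulfur would fall with compound 4 or with compound 3.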